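Ortho-methyl on the aryloxy ring of compound 2

A few compounds are considered here, and "the series" means these few. Any claim that something is new, unique, unknown or untested is made for them only; others in the source may bear on it.

Compound 2 `CCN(Cc1cccs1)C(=O)COc1ccccc1` gives the highest number of the three measured in an assay on HEK293 cells for agonist activity at transient receptor potential cation channel subfamily M member 8 (Homo sapiens), read by fluorescence and calcium flux, with a stated time of 15 min (a higher number here means that more compound is needed for the effect, a lower number that less compound is needed), at 1400 nM. Compound 1 `CCN(Cc1cccs1)C(=O)COc1ccc(F)cc1` gives 422 nM in this assay, and compound 3 `CCN(Cc1cccs1)C(=O)COc1ccc(OC)cc1` gives 120 nM. Both substituted analogues sit below compound 2: a 3.3-fold higher number from compound 1 to compound 2 (0.52 log units; beyond the scatter), and a 12-fold lower number from compound 2 to compound 3 (1.07 log units; beyond the scatter); between the two substituents, a 3.5-fold lower number from compound 1 to compound 3 (0.55 log units; beyond the scatter).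

Compound 4 `CCN(Cc1cccs1)C(=O)COc1ccccc1C` differs from compound 2 by methyl in place of hydrogen on an aromatic carbon. Going by the values given here, no measured step introduces a methyl, and none places a group ortho to a large group; the steps to compound 1 and compound 3 bear only indirectly, showing that in both measured cases a group added to this ring lowered the number in this assay, by a modest to large amount. With the group and its place both unprecedented in the series, the step from compound 2 to compound 4 is expected to be small, if anything a lowering, as a 1.6-fold lower number from compound 2 to compound 4 (0.19 log units; within the scatter). Compound 4 is accordingly estimated at 900 nM in this assay, with a range from 300 nM to 2700 nM.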

Compound 4, half-maximal effective concentration: 192 nM
Estimate against measurement, compound 4: 4.7-fold (0.67 log units) above; measured number outside the range, below it.
By their numbers in this assay, from the lowest: compounds 3 and 4 (each within the scatter of the next); then compound 1; then compound 2.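

Methyl in place of hydrogen, on an aromatic carbon ortho to a large group, gives a 7.3-fold lower number from compound 2 to compound 4 (0.86 log units; beyond the scatter) in this assay, so this place on the ring accepts a group and the number still falls. The entering methyl has 0 hydrogen-bond donors and 0 hydrogen-bond acceptors, so among the compounds shown a lowering on this ring does not depend on the group carrying an acceptor. No measurement on hand accounts for the step.

Open, on these data alone, is whether the lowering belongs to the place or to the group: a chloro or a methoxy ortho to a large group, or the methyl on another ring carbon, would separate the two. Also open, as far as these compounds go, is whether an ethyl or an isopropyl holds the number here, and whether methyl and methoxy add up on one ring.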